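This account rests on a few compounds, and the source may have more. Where it says the series, first, only, none or still open, it means among the compounds named here.

Measured so far in a functional assay on HeLa cells (Homo sapiens) for antiproliferative activity, read by MTT assay, with a stated time of 72 h; on this read-out lower numbers stand for stronger inhibition and higher numbers for weaker inhibition:
compound 1 `COc1cc(-c2nccn2CC(C)C)cc(OC)c1OC` gives > 100000 nM, a limit of the assay and not a number.
compound 2 `COc1cc(-c2nccn2-c2ccc3[nH]ccc3c2)cc(OC)c1OC` gives 4400 nM.

Compound 1 stands at the weak end of the series as far as it can be placed: the limit of > 100000 nM in this assay, at which 1 of the 2 values shown sits, so only a limit and no number is known for it. Compound 3 `COc1ccc(-n2ccnc2-c2cc(OC)c(OC)c(OC)c2)cc1` differs from compound 1 in one place: 4-methoxyphenyl in place of isobutyl on an aromatic nitrogen. Among the compounds with values here, no step between two measured compounds covers this change directly. Compound 2, which also carries an aromatic group on the ring nitrogen of the shared core, gives 4400 nM in this assay. On that basis the change from isobutyl to 4-methoxyphenyl is expected to bring a large gain in this assay, toward stronger inhibition and well beyond the usual scatter. Compound 3 is estimated at 3000 nM, with a range of 500 nM to 20000 nM. This estimate is expected to mean a step of an at least 33-fold lower number from compound 1 to compound 3 (1.52 log units; beyond the scatter).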

Compound 3, half-maximal inhibitory concentration: 1200 nM
Estimate against measurement, compound 3: 2.5-fold (0.40 log units) above; the range from low to high includes it.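

In this assay, 4-methoxyphenyl in place of isobutyl on the aromatic nitrogen gives an at least 83-fold lower number from compound 1 to compound 3 (1.92 log units; beyond the scatter), the first step measured at this position and one that lies beyond the scatter. With compound 2 at 4400 nM and compound 3 at 1200 nM, two different aromatic groups on this nitrogen now give measured numbers, while isobutyl in compound 1 does not. On these data alone, the true size of the step stays unknown because compound 1 sits at a limit of the assay and not at a number: the limit of > 100000 nM in this assay, at which 1 of the 3 values shown sits.

The compounds shown leave open whether the gain comes from the six-membered aromatic ring itself or from its methoxy group. A plain phenyl on this nitrogen would separate the two, and an amine or a carboxylic acid in place of the methoxy would test how much change the ring tolerates.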